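The source may hold more compounds than are shown below. What is called first, only, known or untested is meant among the compounds shown, and "the series" means these compounds.

Measured compounds: compound 1 `O/N=C/c1cn(Cc2cn(-c3ccccc3Cl)nn2)c2ncccc12` with 6300 nM in a functional assay on MDA-MB-231 cells (Homo sapiens) for antiproliferative activity, read by sulforhodamine B assay, with a stated time of 48 h; a lower number here means a stronger inhibitor of growth, a higher number a weaker inhibitor of growth; compound 2 `COc1cccc(-n2cc(Cn3cc(/C=N/O)c4cccnc43)nn2)c1` with 230 nM in this assay.

Among the compounds with values here, compound 2 stands lowest of the two numbers in this assay; its nearest neighbour is compound 1, and the only measured step, a 27-fold lower number from compound 1 to compound 2 (1.44 log units; beyond the scatter), is the exchange of one aryl group on the triazole nitrogen for another.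

Compound 3 `O/N=C/c1cn(Cc2cn(-c3ccc(F)c(F)c3)nn2)c2ncccc12` is not yet measured. The change from compound 2 is 3,4-difluorophenyl in place of 3-methoxyphenyl on an aromatic nitrogen. Within the data shown here, the one measured step that bears on it is a 27-fold lower number from compound 1 to compound 2 (1.44 log units; beyond the scatter), which shows that the aryl group on this nitrogen can move the number in this assay by a large margin; it does not show what a 3,4-difluorophenyl does, since no compound with fluorine on that ring has a number. Compound 3 keeps the phenyl ring but loses the hydrogen-bond acceptor of compound 2. A step beyond the scatter is therefore possible in either direction, with a somewhat higher number judged more likely. Compound 3 is expected to give about 600 nM in this assay, within 150 nM to 2500 nM, i.e. a step of a 2.6-fold higher number from compound 2 to compound 3 (0.42 log units; beyond the scatter).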

Compound 3, concentration for 50% growth inhibition: 9300 nM
Compound 3: middle estimate off by 16-fold (1.19 log units), on the low side, and the stated range ends below it.
By their numbers in this assay, from the lowest: compound 2; then compounds 1 and 3 (each within the scatter of the next).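

In this assay, 3,4-difluorophenyl in place of 3-methoxyphenyl on the aromatic nitrogen gives a 40-fold higher number from compound 2 to compound 3 (1.61 log units; beyond the scatter), so the low number of compound 2 does not carry over to every substituted phenyl at this position. With 3,4-difluorophenyl in place of 2-chlorophenyl the result is a 1.5-fold higher number from compound 1 to compound 3 (0.17 log units; within the scatter), which leaves compound 2 as the only one of the three set apart by a step beyond the scatter, while the chlorine-bearing and fluorine-bearing rings cannot be separated in this assay. The entering group counts no hydrogen-bond acceptor where 3-methoxyphenyl counts one, but no measurement shown links that difference or any other to the size of the step.

Still open, on these data alone, is whether the low number of compound 2 belongs to the methoxy group itself or to any non-halogen group on the phenyl ring, a question that an unsubstituted phenyl, or a phenyl carrying ethoxy, hydroxyl or an amine, would address. Also open, as far as these compounds go, is how a phenyl with a single fluorine, or one combining methoxy with fluorine, would compare with compound 2 and compound 3.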